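The source may hold more compounds than are shown below. What is called first, only, known or untested is meant among the compounds shown, and "the series" means these compounds.

Measured so far in an ADME assay on HEK293 cells (Homo sapiens) for inhibition, read by MTT assay, with a stated time of 3 days; on this read-out higher numbers stand for weaker inhibition and lower numbers for stronger inhibition:
- compound 1 `COc1ccc(/C=C\c2cc(OC)c(OC)c(OC)c2)cc1OCc1ccccc1`: 15000 nM
- compound 2 `COc1ccc(/C=C\c2cc(OC)c(OC)c(OC)c2)cc1OCc1ccc(Br)cc1`: 45000 nM

Not yet measured: compound 3 `COc1ccccc1/C=C/CCCOc1cc(/C=C\c2cc(OC)c(OC)c(OC)c2)ccc1OC`.

Of the two measured compounds, compound 2 has the higher number in this assay, at 45000 nM, which means the weaker inhibition. The next change, to compound 3, falls on a saturated chain carbon bound to an oxygen on an aromatic ring: 4-(2-methoxyphenyl)but-3-en-1-yl in place of 4-bromophenyl on a saturated chain carbon bound to an oxygen on an aromatic ring.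

Among the measured compounds shown here, only one measured step bears on this, and only indirectly. It is a 3.0-fold higher number from compound 1 to compound 2 (0.48 log units; beyond the scatter), modest but beyond the scatter, and it concerns bromo in place of hydrogen on an aromatic carbon. For the measured compounds named here, no measured compound carries 4-(2-methoxyphenyl)but-3-en-1-yl, so the direction of any change remains open. With so little to go on, no step beyond the scatter is expected in this assay, and the uncertainty stays wide. The expected change is a 1.5-fold lower number from compound 2 to compound 3 (0.18 log units; within the scatter). For compound 3 the estimated value is 30000 nM, with an expected range from 9000 nM to 100000 nM.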

Compound 3, half-maximal inhibitory concentration: > 400000 nM
Compound 3: only a limit was reported; the forecaster's own chance of this, stated with the estimate: 15%; middle value at least 13-fold (1.12 log units) away from the limit.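

Compound 3 sits at the top of the values reported in this assay, and its entry is a limit of the assay and not a number: the limit of > 400000 nM in this assay, at which 1 of the 3 values shown sits.

At the place described as a saturated chain carbon bound to an oxygen on an aromatic ring, 4-(2-methoxyphenyl)but-3-en-1-yl in place of 4-bromophenyl gives an at least 8.8-fold higher number from compound 2 to compound 3 (0.94 log units; beyond the scatter), and the same group in place of phenyl gives an at least 26-fold higher number from compound 1 to compound 3 (1.42 log units; beyond the scatter). The earlier pair showed only a bromo change on the aromatic ring, with a 3.0-fold higher number from compound 1 to compound 2 (0.48 log units; beyond the scatter), whereas these steps replace the group at this place as a whole and show that inhibition in this read-out can weaken much further than that bromo step alone indicated.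

Compound 3 brings in the chain, its double bond and the methoxy group together, so the compounds shown do not assign the weaker inhibition to any one of these. Also open, from the compounds shown here alone, is how a saturated butyl chain, or a chain ending in an amine or a carboxylic acid, would read at this place in this assay.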